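Swapping 4-Methylcyclohexyl for Dimethylamino on a Carbonyl Carbon

The source may hold more compounds than are shown below. What is called first, only, known or untested is meant among the compounds shown, and "the series" means these compounds.

Of the compounds shown here, three built on a shared core have been tested in a functional assay on HCT-116 cells (Homo sapiens) for cytotoxicity, read by sulforhodamine B assay, with a stated time of 48 h; a higher number here means a weaker inhibitor, a lower number a stronger inhibitor. Compound 1 `CCCCNC(=O)N1Cc2c(NC(=O)c3ccc(OC)cc3)nn(C(=O)c3ccccc3)c2C1` gives 25300 nM, the highest number of the three. Compound 2 `O=C(Nc1nn(C(=O)C2CC2)c2c1CN(C(=O)c1ccccc1)C2)c1ccccc1` gives 1240 nM, the lowest. Compound 3 `CC(=O)n1nc(NC(=O)c2ccccc2)c2c1CN(C(=O)C1CCC(C)CC1)C2` falls in the middle at 12200 nM, clearly apart from both neighbours.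

Compound 4 `CC(=O)n1nc(NC(=O)c2ccccc2)c2c1CN(C(=O)N(C)C)C2` has not yet been measured. It differs from compound 3 in one place, with dimethylamino in place of 4-methylcyclohexyl on a carbonyl carbon.

For the measured compounds named here, no two measured compounds differ in just one place, so this forecast is rough. It leans on compound 1, which also has a nitrogen on that carbonyl carbon and gives 25300 nM, so a drift toward weaker inhibition seems more likely than a gain. The estimated step of a 1.5-fold higher number from compound 3 to compound 4 (0.17 log units; within the scatter) is expected to be small and to stay within the usual scatter. For compound 4 the estimated value is 18000 nM, with an expected range from 6000 nM to 50000 nM.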

Compound 4, half-maximal inhibitory concentration: 70300 nM
Compound 4: middle estimate off by 3.9-fold (0.59 log units), on the low side, and the stated range ends below it.
By their numbers in this assay, from the lowest: compound 2; then compound 3; then compound 1; then compound 4.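

For the compounds shown here, this is the first reading at this position in which only one place changes, on a carbonyl carbon whose other neighbour is an amide-type nitrogen in a ring. In this assay, putting dimethylamino in place of 4-methylcyclohexyl gives a 5.8-fold higher number from compound 3 to compound 4 (0.76 log units; beyond the scatter), a step beyond the usual scatter, so this position does respond to what it carries, and here the change weakens inhibition. No measurement at hand accounts for this loss.

The compounds shown leave open whether the loss follows the removal of the carbon ring, the drop from seven heavy atoms to three, or the arrival of the nitrogen. An isopropyl group or a piperidine ring on the same carbonyl carbon would help to separate these possibilities.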